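The source may report more compounds than this note shows. Statements on the series, on what has been measured and on what is new or still open speak of the compounds shown alone.

Of the compounds shown here, two sharing one core have been measured so far. In a functional assay on B16-F0 cells (Mus musculus) for inhibition, read by CCK-8 assay, with a stated time of 48 h (on this read-out higher numbers stand for weaker inhibition and lower numbers for stronger inhibition), compound 1 `COc1cc(-c2ccnc3cc(-c4ccc(Cl)cc4)nn23)cc(OC)c1OC` gives 4090 nM. Compound 2 `COc1cc(-c2ccnc3cc(-c4ccc(C(C)=O)cc4)nn23)cc(OC)c1OC` gives 3930 nM in this assay. Compound 2 thus stands at the low end of the two numbers, yet the gap to compound 1 is slight: the step of a 1.0-fold lower number from compound 1 to compound 2 (0.02 log units; within the scatter). Compound 3 `COc1cc(-c2ccnc3cc(-c4ccc(F)cc4)nn23)cc(OC)c1OC` is the compound not yet measured. Compared with compound 2 it changes in this way: fluoro in place of acetyl on an aromatic carbon. For the measured compounds named here, only one measured step bears on such a change at this place, namely a 1.0-fold lower number from compound 1 to compound 2 (0.02 log units; within the scatter), which swapped one group for another there and left the number essentially where it was. Since that swap also involved a halogen and an acetyl group, the expected step of a 1.0-fold higher number from compound 2 to compound 3 (0.01 log units; within the scatter) is small, with no direction beyond the scatter. Compound 3 is therefore estimated at 4000 nM in this assay, with a range from 1800 nM to 9000 nM.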

Compound 3, half-maximal inhibitory concentration: 4540 nM
Compound 3: the middle estimate sits 1.1-fold (0.05 log units) below what was measured; the measured number falls inside the stated range.
By their numbers in this assay, from the lowest: compounds 2, 1 and 3 (each within the scatter of the next).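

In this assay, replacing acetyl with the much smaller fluoro gives (a 1.2-fold higher number from compound 2 to compound 3 (0.06 log units; within the scatter)), even though acetyl has 3 heavy atoms and a hydrogen-bond acceptor, while fluoro has 1 heavy atom and no acceptor. Exchanging one halogen for another on the same aromatic carbon gives (a 1.1-fold higher number from compound 1 to compound 3 (0.05 log units; within the scatter)). Compounds 1, 2 and 3 therefore cannot be told apart at this position, so these three groups give no ranking, and no supporting evidence is available to explain this result.

From the compounds shown here alone, it remains open whether an amine, a carboxylic acid or a longer chain at this carbon would move the number beyond the scatter. The three methoxy groups of the shared core are also the same in all three compounds, so what they contribute cannot be judged.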